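This account rests on a few compounds, and the source may have more. Where it says the series, first, only, none or still open, it means among the compounds named here.

In an assay on cells for positive allosteric modulation of Cystic fibrosis transmembrane conductance regulator variant F508del (Homo sapiens), with stated times of 10 min and 7 s, in the presence of a further agent that is not named here (on this read-out lower numbers stand for an effect already at smaller amounts and higher numbers for an effect only at larger amounts of compound), compound 1 `CC1(C)Cc2c(sc(NC(=O)c3nnc[nH]3)c2C(N)=O)C(C)(C)O1` gives 467 nM. Compound 2 `CC1(C)Cc2c(sc(NC(=O)C3(O)CC3)c2C(N)=O)C(C)(C)O1` gives 23 nM, and compound 3 `CC1(C)Cc2c(sc(NC(=O)C(C)(C)CO)c2C(N)=O)C(C)(C)O1` gives 75 nM. Compound 3 thus stands second highest of the three numbers, with a 3.3-fold higher number from compound 2 to compound 3 (0.51 log units; beyond the scatter) and a 6.2-fold lower number from compound 1 to compound 3 (0.79 log units; beyond the scatter). The next compound, compound 4 `Cc1cc(C(=O)Nc2sc3c(c2C(N)=O)CC(C)(C)OC3(C)C)[nH]n1`, differs from compound 3 by 3-methyl-1H-pyrazol-5-yl in place of 1-(hydroxymethyl)-1-methylethyl on a carbonyl carbon. The step that bears most on this is a 6.2-fold lower number from compound 1 to compound 3 (0.79 log units; beyond the scatter), where the triazolyl group, an aromatic five-membered ring with hetero atoms, gave way to the open chain; compound 4 brings such a ring back, so a step in the opposite direction, towards a higher number, is expected. Compound 4 is therefore expected to give 250 nM, within a range from 80 nM to 800 nM. The expected step is a 3.3-fold higher number from compound 3 to compound 4 (0.52 log units; beyond the scatter).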

Compound 4, half-maximal effective concentration: 13 nM
Compound 4: the middle estimate sits 19-fold (1.28 log units) above what was measured; measured number outside the range, below it.
By their numbers in this assay, from the lowest: compounds 4 and 2 (each within the scatter of the next); then compound 3; then compound 1.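

The 3-methyl-1H-pyrazol-5-yl group shows that an aromatic five-membered ring on this carbonyl carbon need not push the number up, since the change from the open chain goes the other way (a 5.8-fold lower number from compound 3 to compound 4 (0.76 log units; beyond the scatter)). Ring identity matters here, as the change from 4H-1,2,4-triazol-3-yl shows (a 36-fold lower number from compound 1 to compound 4 (1.56 log units; beyond the scatter)), while the change from 1-hydroxycyclopropyl gives no order (a 1.8-fold lower number from compound 2 to compound 4 (0.25 log units; within the scatter)). Nothing available accounts for these differences.

On these data alone, it remains open whether the methyl on the pyrazole ring contributes, and how a phenyl ring or a carboxylic acid would read on this carbonyl carbon.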